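The source may hold more compounds than are shown below. What is called first, only, known or untested is meant among the compounds shown, and "the series" means these compounds.

In a functional assay on CCRF-CEM cells (Homo sapiens) for cytotoxicity, read by sulforhodamine B assay, with a stated time of 48 h (on this read-out lower numbers stand for higher toxicity in this test and higher numbers for lower toxicity in this test), compound 2 `ClCc1ccccc1Cn1cnc2c(Cl)ncnc21` gives 8120 nM. Compound 1 `ClCc1ccccc1Cn1cnc2c(Cl)nc(Cl)nc21` differs from it by chloro in place of hydrogen on an aromatic carbon, and in this assay compound 1 gives 470 nM, which is a 17-fold lower number from compound 2 to compound 1 (1.24 log units; beyond the scatter). Compound 3 `ClCc1cccc(Cn2cnc3ncnc(Cl)c32)c1` has the same atoms as compound 2 joined differently; the difference between the two cores is not broken down here. In this assay compound 3 gives 60300 nM. Compound 4 `ClCc1cccc(Cn2cnc3nc(Cl)nc(Cl)c32)c1` differs from compound 3 by chloro in place of hydrogen on an aromatic carbon, at a place described in exactly the same words as in the earlier change, so it is the same change. Among the compounds with values here, the step of a 17-fold lower number from compound 2 to compound 1 (1.24 log units; beyond the scatter) is the only guide to its size. Resting on that single example, for compound 4 a step of a 15-fold lower number from compound 3 to compound 4 (1.18 log units; beyond the scatter) is expected. Compound 4 is therefore estimated at 4000 nM, with a likely range from 1500 nM to 12000 nM.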

Compound 4, concentration lethal to 50% of the cells: 5490 nM
Beside the measured number, compound 4's estimate is 1.4-fold (0.14 log units) below it, and the stated range covers the measured number.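

In this assay, chloro in place of hydrogen on the aromatic carbon between two ring nitrogen atoms again gives a large change, an 11-fold lower number from compound 3 to compound 4 (1.04 log units; beyond the scatter), meaning higher toxicity in this test. The size of the step carries over between these two cores: the same change on two cores in this assay, a 17-fold lower number (1.24 log units; beyond the scatter) from compound 2 to compound 1 and an 11-fold lower number (1.04 log units; beyond the scatter) from compound 3 to compound 4, 1.6-fold (0.20 log units) apart, within the scatter of two such steps. Within the data shown here, this is only two cores in one cell test, so it does not show that the step would hold on any other core, and it does not explain why the change acts as it does.

From the compounds shown here alone, what an amine or a methoxy group would do at the same place remains open. So does the effect of a bromo group there.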